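Phenyl in Place of Pyridyl on a Weak Cytotoxic Core

A few compounds are considered here, and "the series" means these few. Any claim that something is new, unique, unknown or untested is made for them only; others in the source may bear on it.

Compound 1 `Oc1ccc(-c2cc(-c3cccnc3)nc(-c3cccc(Cl)c3)c2)cc1`: 22900 nM
Compound 2 `Oc1ccc(-c2cc(-c3cccnc3)nc(-c3ccccc3Cl)c2)cc1`: "not determined" (no result reported)

Among the compounds with values here, in a functional assay on DU-145 cells (Homo sapiens) for cytotoxicity, read by CCK-8 assay and cell counting, with a stated time of 2 days (a higher number here means a weaker inhibitor, a lower number a stronger inhibitor), compound 1 gives 22900 nM, the only number in this set; for compound 2 the entry reads "not determined" (no result reported). Compound 3 `Oc1ccc(-c2cc(-c3ccccc3)nc(-c3cccc(Cl)c3)c2)cc1` differs from compound 1 by phenyl in place of pyridin-3-yl on an aromatic carbon. Within the data shown here, no step between two measured compounds is available, so nothing here tells how large such a change is; the expectation is a step within the usual scatter, in no particular direction. For compound 3 the expected step is a 1.0-fold lower number from compound 1 to compound 3 (0.02 log units; within the scatter). Compound 3 is therefore estimated at 22000 nM, with a range from 8000 nM to 60000 nM.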

Compound 3, half-maximal inhibitory concentration: 5360 nM
Compound 3: middle estimate off by 4.1-fold (0.61 log units), on the high side, outside the stated range (below it).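

In this assay, phenyl in place of pyridin-3-yl on this aromatic carbon, next to the ring nitrogen, brings a 4.3-fold lower number from compound 1 to compound 3 (0.63 log units; beyond the scatter). The position therefore responds to the exchange of a single ring atom, and a hydrogen-bond acceptor in the leaving ring is not required for the activity of the shared core. Nothing measured here explains the step. From the compounds shown here alone, whether a methoxy group or an amine on the entering phenyl would move the number further remains open, as does whether the same step holds with the chlorine placed as in compound 2, which has no number.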